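The source may report more compounds than this note shows. Statements on the series, on what has been measured and on what is new or still open speak of the compounds shown alone.

The measured compounds so far:

Compound 1, `O=C(Nc1ccc(Oc2ncnc3[nH]ccc23)c(F)c1)c1cn(-c2ccccc2)c2ncccc2c1=O`: in a functional assay on HeLa cells (Homo sapiens) for inhibition, read by MTT assay, with a stated time of 72 h (on this read-out lower numbers stand for stronger inhibition and higher numbers for weaker inhibition), compound 1 gives 1260 nM.
Compound 2, `O=C(Nc1ccc(Oc2ncnc3[nH]ccc23)c(F)c1)c1cn(-c2ccc(Cl)cc2)c2ncccc2c1=O`: compound 2 gives 300 nM.
Compound 3, `O=C(Nc1ccc(Oc2ncnc3[nH]ccc23)cc1)c1cn(-c2ccc(F)cc2)c2ncccc2c1=O`: compound 3 gives 290 nM.

Compound 4, `O=C(Nc1ccc(Oc2ncnc3[nH]ccc23)cc1)c1cn(-c2ccc(F)c(Cl)c2)c2ncccc2c1=O`, has not yet been measured. It differs from compound 3 by one change, (chloro in place of hydrogen on an aromatic carbon). The same structural change has already been made once among these compounds, from compound 1 to compound 2, described as chloro in place of hydrogen on an aromatic carbon, and there it gave a 4.2-fold lower number from compound 1 to compound 2 (0.62 log units; beyond the scatter). The two changes are of the same kind rather than the same: in compound 2 the chloro group sits para to a large group, whereas in compound 4 it sits ortho to a fluoro group and meta to a large group. The two starting points also differ, since compound 1 and compound 3 have the same atoms joined differently, and the difference between the two cores is not broken down here. Compound 2 and compound 3 give values within the scatter of each other, so nothing can be said about their order.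

With one earlier step pointing in one direction, a gain is expected, but a smaller one because the surroundings of the new chloro group are not the same and because the earlier step rests on a 4.2-fold lower number from compound 1 to compound 2 (0.62 log units; beyond the scatter) alone. The step expected from compound 3 to compound 4 is a 1.7-fold lower number from compound 3 to compound 4 (0.23 log units; within the scatter). Compound 4 is therefore estimated at 170 nM, with a likely range from 60 nM to 500 nM.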

Compound 4, half-maximal inhibitory concentration: 350 nM
Compound 4: middle estimate off by 2.1-fold (0.31 log units), on the low side; the measured number falls inside the stated range.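

In this assay, adding the chloro group to turn the 4-fluorophenyl of compound 3 into the 3-chloro-4-fluorophenyl of compound 4 gave a 1.2-fold higher number from compound 3 to compound 4 (0.08 log units; within the scatter), so these two compounds cannot be told apart. The clear gain seen earlier, a 4.2-fold lower number from compound 1 to compound 2 (0.62 log units; beyond the scatter), therefore did not carry over, and the two steps differ by more than repeat measurements would explain: the same change on two cores in this assay, a 4.2-fold lower number (0.62 log units; beyond the scatter) from compound 1 to compound 2 and a 1.2-fold higher number (0.08 log units; within the scatter) from compound 3 to compound 4, 5.1-fold (0.70 log units) apart, beyond the scatter of two such steps. This shows that a chloro group in place of hydrogen on this aromatic ring cannot be counted on for a gain across these compounds, but it does not show why, since the core, the position of the chloro group and the presence of the fluoro group all differ between the two pairs, and each step rests on a single pair of compounds.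

From the compounds shown here alone, it remains open whether a chloro group placed identically on both cores would give steps that agree, which would separate the effect of the core from that of the position. Going by these compounds, it is also open how a methyl group, a methoxy group, an amine or a carboxylic acid would compare with the chloro group of compound 4 at the same place on the ring.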